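The source may hold more compounds than are shown below. What is called first, only, known or untested is meant among the compounds shown, and "the series" means these compounds.

Measured compounds:
Compound 1 `CC1(COc2ccc(-c3ccc(C(F)(F)F)cc3)cn2)Cn2cc([N+](=O)[O-])nc2O1` in an ADME assay on MRC5 cells (Homo sapiens) for cytotoxicity, read by fluorescence, with a stated time of 72 h (on this read-out higher numbers stand for weaker inhibition and lower numbers for stronger inhibition), gives > 64000 nM.
Compound 2 `CC1(COc2ccc(-c3ccc(C(F)(F)F)cc3)nc2)Cn2cc([N+](=O)[O-])nc2O1` in this assay gives > 64000 nM.
Compound 3 `CC1(COc2ccc(-c3ccc(F)nc3)cn2)Cn2cc([N+](=O)[O-])nc2O1` in this assay gives > 64000 nM.

For compound 1 the reading is a limit of this assay, not a number. For compound 2 the reading is likewise a limit. For compound 3 the reading is also a limit. Compound 1 and compound 3 differ in one place: 6-fluoropyridin-3-yl in place of 4-(trifluoromethyl)phenyl on an aromatic carbon. The step this made, a step that the two limits leave unreadable from compound 1 to compound 3, cannot be sized because both ends sit at a limit. Compound 2 is built from the same atoms as compound 1, joined differently; the difference between the two cores is not broken down here.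

Compound 4 `CC1(COc2ccc(-c3ccc(F)nc3)nc2)Cn2cc([N+](=O)[O-])nc2O1` has not yet been measured in this assay. It differs from compound 2 by 6-fluoropyridin-3-yl in place of 4-(trifluoromethyl)phenyl on an aromatic carbon. This is the same kind of change as that from compound 1 to compound 3, but the surroundings are not identical: in compound 3 the entering group sits two atoms from the ring nitrogen, whereas in compound 4 it sits next to the ring nitrogen. The step from compound 2 to compound 4 is expected to be a number no higher from compound 2 to compound 4 (the limit leaves the size open), resting on (the limit of > 64000 nM in this assay, at which 3 of the 3 values shown sit). Compound 4 is therefore expected to give 64000 nM in this assay. For compound 4 the expected range runs from 30000 nM to 150000 nM, with the reading most likely again a limit rather than a number.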

Compound 4, half-maximal inhibitory concentration: > 64000 nM
Compound 4 was reported as a limit; the forecaster's own chance of this, stated with the estimate: 85%; the middle value lies on the limit itself.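

For the compounds shown here, compound 2 and compound 4 both read as a limit in this assay, not as a number, so the step between them cannot be read and no new step comes from this result. The compounds shown leave open whether 6-fluoropyridin-3-yl in place of 4-(trifluoromethyl)phenyl changes this read-out at all, and what number any of them would give, with all readings resting on one point: the limit of > 64000 nM in this assay, at which 4 of the 4 values shown sit.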